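Alpha-1 binding: fluoro to nitro on the aryl piperazine

This account rests on a few compounds, and the source may have more. Where it says the series, first, only, none or still open, it means among the compounds named here.

Measured compounds in an assay on isolated protein for binding affinity to Adrenergic receptor alpha-1 (Rattus norvegicus), read by radioligand binding; on this read-out higher numbers stand for weaker inhibition and lower numbers for stronger inhibition:
Compound 1, `O=C1C2CCCN2C(=O)N1CN1CCN(c2ccc(F)cc2)CC1`, gives a limit of the assay, > 1000 nM.
Compound 2, `O=C1C2CCCN2C(=O)N1CN1CCN(c2ccc([N+](=O)[O-])cc2)CC1`, gives a limit of the assay, > 10000 nM.
Compound 3, `O=C1C2CCCN2C(=O)N1CCCN1CCN(c2ccc(F)cc2)CC1`, gives 25.2 nM.

Compound 2 differs from compound 1 by nitro in place of fluoro on an aromatic carbon. The step from compound 1 to compound 2 is a step that the two limits leave unreadable from compound 1 to compound 2; it cannot be read because compound 1 sits at the limit of > 1000 nM in this assay, at which 1 of the 3 values shown sits, and compound 2 sits at the limit of > 10000 nM in this assay, at which 1 of the 3 values shown sits. Compound 3 carries the same fluorophenyl piperazine on a different core; the difference between the two cores is not broken down here. Within the data shown here, compound 3 is the only member of the three with a number rather than a limit in this assay.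

Compound 4, `O=C1C2CCCN2C(=O)N1CCCN1CCN(c2ccc([N+](=O)[O-])cc2)CC1`, is not yet measured. It differs from compound 3 by nitro in place of fluoro on an aromatic carbon, the same change as that from compound 1 to compound 2, made around the same kind of place. Among the measured compounds shown here, the one earlier instance of this change gives no readable size, so the step from compound 3 to compound 4 cannot be anchored on it. For the measured compounds named here, compound 4 is expected to bind somewhat more weakly than compound 3 in this assay, with an estimated step of a 4.0-fold higher number from compound 3 to compound 4 (0.60 log units; beyond the scatter), and with wide uncertainty because the only precedent is a step that the two limits leave unreadable from compound 1 to compound 2. The estimate for compound 4 in this assay is 100 nM, expected to fall between 25 nM and 400 nM.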

Compound 4, inhibition constant: > 1000 nM
Compound 4: no number, only a limit; the forecaster's own chance of this, stated with the estimate: 5%; middle value at least 10-fold (1.00 log units) from the limit.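

In this assay, nitro in place of fluoro, carried onto the core where the fluoro member has a number, gives an at least 39-fold higher number from compound 3 to compound 4 (1.59 log units; beyond the scatter), so on this core the change clearly costs binding. That step is a floor and not a size, because compound 4 sits at a limit of the assay: the limit of > 1000 nM in this assay, at which 2 of the 4 values shown sit. On the core of compound 1 both members sit at limits and the step there cannot be read, so the two cores cannot be compared: the notes show a loss on one core and say nothing on whether the change has the same size on the other.

As far as these compounds go, the true size of the loss on the core of compound 3 stays open, as does whether it belongs to nitro alone or would also follow other groups at the same place on the aromatic ring, such as an amine, a nitrile or a carboxylic acid. Also open, from the compounds shown here alone, is whether a longer chain between the core and the piperazine would keep the fluoro value of compound 3, 25.2 nM, or change how the nitro member reads.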